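Sulfonyl aryl variation from compound 3 to compound 4

The source may report more compounds than this note shows. Statements on the series, on what has been measured and on what is new or still open speak of the compounds shown alone.

Compound 3 `CC(C)Cc1cc(CNS(=O)(=O)c2c(Cl)cccc2Cl)nn1-c1ccccc1` gives 59.4% in an assay on isolated protein for binding affinity to 5-hydroxytryptamine receptor 6 (Homo sapiens), tested at 10 uM (a lower number here means less inhibition, a higher number more inhibition at the concentration tested (going by the name of the read-out)), the second highest of the three numbers recorded. Compound 1 `CC(C)Cc1cc(CNS(=O)(=O)c2ccc(C(C)(C)C)cc2)nn1-c1ccccc1` gives 51.1% and compound 2 `CC(C)Cc1cc(CNS(=O)(=O)c2ccc3ccccc3c2)nn1-c1ccccc1` gives 67.8% in this assay. The steps of a number 8.3 percentage points higher from compound 1 to compound 3 (within the scatter) and a number 8.4 percentage points lower from compound 2 to compound 3 (within the scatter) both stay within the scatter; only a number 16.7 percentage points higher from compound 1 to compound 2 (beyond the scatter) moves beyond it, and that shift is modest. Compound 4 `Cc1c(Cl)cccc1S(=O)(=O)NCc1cc(CC(C)C)n(-c2ccccc2)n1` differs from compound 3 as follows: 3-chloro-2-methylphenyl in place of 2,6-dichlorophenyl on a sulfonyl sulfur. Each measured step swaps one group on the sulfonyl sulfur, and none exceeds a modest change, so compound 4 is expected to stay in the same band, with a number 2.4 percentage points lower from compound 3 to compound 4 (within the scatter) as the expected step. For compound 4 the estimate is 57%, with a range from 40% to 72%.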

Compound 4, a percentage reported as inhibition, at one concentration (the size of the read-out at that concentration, not a potency): 72.3%
Beside the measured number, compound 4's estimate is 15.3 percentage points below it; the measured number lies above the stated range.
By their numbers in this assay, from the lowest: compounds 1, 3, 2 and 4 (each within the scatter of the next, the first and the last beyond it).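

On a sulfonyl sulfur, exchanging one chlorine-bearing phenyl for another still moves the read-out in this assay: the swap gives a number 12.9 percentage points higher from compound 3 to compound 4 (beyond the scatter) and so this position responds to changes within chlorinated phenyl groups. The widest gap in the set is a number 21.2 percentage points higher from compound 1 to compound 4 (beyond the scatter), whereas a number 4.5 percentage points higher from compound 2 to compound 4 (within the scatter) leaves 3-chloro-2-methylphenyl and naphthalen-2-yl unseparated. No evidence is available that bears on this result.

The compounds shown do not separate the contribution of the chlorine from that of the methyl in 3-chloro-2-methylphenyl. On these data alone, how a phenyl carrying an amine or a carboxylic acid would behave on this sulfur also remains open.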